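The compounds below may be only part of what the source reports. "The series", "measured", "known", "first", "only" and "open" are said of these compounds alone.

Measured compounds:
Compound 1 `CC(C)=CCC[C@H](C)[C@H]1c2cc(C(=O)NCc3ccccc3)c(OC(=O)C(C)(C)C)c(OC(=O)C(C)(C)C)c2[C@H](C)C[C@H]1OC(=O)C(C)(C)C`: 40000 nM
Compound 2 `CC(C)=CCC[C@H](C)[C@H]1c2cc(C(=O)NCc3ccc(Cl)cc3)c(OC(=O)C(C)(C)C)c(OC(=O)C(C)(C)C)c2[C@H](C)C[C@H]1OC(=O)C(C)(C)C`: 40000 nM

In an ADME assay on HEK293 cells (Homo sapiens) for inhibition, read by resazurin assay, with a stated time of 72 h (on this read-out lower numbers stand for stronger inhibition and higher numbers for weaker inhibition), compound 2 gives 40000 nM, which stands level with compound 1 within the scatter; the step of no change at the digits printed from compound 1 to compound 2 (within the scatter) was flat. Compound 3 `CC(C)=CCC[C@H](C)[C@H]1c2cc(C(=O)NCc3ccc(F)cc3)c(OC(=O)C(C)(C)C)c(OC(=O)C(C)(C)C)c2[C@H](C)C[C@H]1OC(=O)C(C)(C)C` is not yet measured and differs from compound 2 by one change: fluoro in place of chloro on an aromatic carbon. Within the data shown here, the only measured step that bears on this change, no change at the digits printed from compound 1 to compound 2 (within the scatter), showed no shift beyond the scatter, and nothing further separates the two substituents in the available numbers. Compound 3 is therefore expected to show no step beyond the scatter, no change at the digits printed from compound 2 to compound 3 (within the scatter). Compound 3 is estimated at 40000 nM, with a range from 20000 nM to 80000 nM.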

Compound 3, half-maximal inhibitory concentration: 80000 nM
Compound 3: the middle estimate sits 2.0-fold (0.30 log units) below what was measured; measured number inside the range.
By their numbers in this assay, from the lowest: compounds 1, 2 and 3 (each within the scatter of the next).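

In this assay, fluoro at this position gives a 2.0-fold higher number from compound 2 to compound 3 (0.30 log units; within the scatter) and, against the unsubstituted benzyl, a 2.0-fold higher number from compound 1 to compound 3 (0.30 log units; within the scatter). With both chloro and fluoro now tested, neither halogen moves the number beyond the scatter, so this position shows no sensitivity to either exchange. The compounds shown leave open whether a methoxy group or an amine on this ring, or a longer chain in place of the benzyl, would shift the number, and they say nothing about changes to the pivaloyl esters on the shared core. No measurement here offers an explanation for these numbers.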